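Compound 4: fluoro in place of hydroxy

A few compounds are considered here, and "the series" means these few. Any claim that something is new, unique, unknown or untested is made for them only; others in the source may bear on it.

Measured in a functional assay on HT-29 cells (Homo sapiens) for cytotoxicity, read by sulforhodamine B assay; on this read-out lower numbers stand for stronger inhibition and higher numbers for weaker inhibition:
- compound 1 `C=C1[C@@H](OC(C)=O)C[C@@H]2[C@](C)(COC=O)[C@H](OC(C)=O)CC[C@@]2(C)[C@@H]1C[C@@H](Nc1ccc(O)cc1)C1=CCOC1=O`: 13400 nM
- compound 2 `C=C1[C@@H](OC(C)=O)C[C@@H]2[C@](C)(CO[Si](C)(C)C(C)(C)C)[C@H](OC(C)=O)CC[C@@]2(C)[C@@H]1C[C@@H](Nc1ccccc1F)C1=CCOC1=O`: 3710 nM
- compound 3 `C=C1[C@@H](OC(C)=O)C[C@@H]2[C@](C)(CO[Si](C)(C)C(C)(C)C)[C@H](OC(C)=O)CC[C@@]2(C)[C@@H]1C[C@@H](Nc1cccc(F)c1)C1=CCOC1=O`: 4520 nM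

Compound 1 has the highest number of the three, beyond the scatter from each of the others. Compound 4 `C=C1[C@@H](OC(C)=O)C[C@@H]2[C@](C)(COC=O)[C@H](OC(C)=O)CC[C@@]2(C)[C@@H]1C[C@@H](Nc1ccc(F)cc1)C1=CCOC1=O` keeps the rest of compound 1 and differs in one place: fluoro in place of hydroxy on an aromatic carbon. This is fluoro in place of hydroxy on an aromatic carbon, para to a large group. Among the compounds with values here, no measured step covers this exchange directly. Within the data shown here, the one step available, a 1.2-fold higher number from compound 2 to compound 3 (0.09 log units; within the scatter), only moves the fluoro and stays within the scatter. Compound 2 and compound 3 both carry fluoro and show lower numbers than compound 1, but they also differ from it elsewhere, so only part of that gap is expected to carry over. A modest move to a lower number is expected, estimated as a 1.8-fold lower number from compound 1 to compound 4 (0.25 log units; within the scatter). For compound 4 the estimated value is 7500 nM, with an expected range of 3500 nM to 15000 nM.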

Compound 4, half-maximal inhibitory concentration: 20500 nM
Beside the measured number, compound 4's estimate is 2.7-fold (0.44 log units) below it; measured number outside the range, above it.
By their numbers in this assay, from the lowest: compounds 2 and 3 (each within the scatter of the next); then compounds 1 and 4 (each within the scatter of the next).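

In this assay, the exchange on the para position of the (4-hydroxyphenyl)amino group gives a 1.5-fold higher number from compound 1 to compound 4 (0.18 log units; within the scatter), so hydroxy and fluoro are not separated here. Losing the hydrogen-bond donor and acceptor counted for hydroxy therefore brings no resolved change at this position in this core. No supporting measurement bears on this result.

As far as these compounds go, whether a methoxy group or an amine at this position would separate from hydroxy and fluoro remains open. Also open, from the compounds shown here alone, is what sets compounds 2 and 3 apart from compounds 1 and 4, since these pairs differ in more than one place.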